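This account rests on a few compounds, and the source may have more. Where it says the series, first, only, none or still open, it means among the compounds named here.

Compound 1 `Cc1nc(SCC(=O)Nc2nc(-c3ccc(Cl)cc3)cs2)n(Nc2ccccc2)c1C` stands alone with a numerical result among the compounds shown: in a functional assay on NCI-H23 cells (Homo sapiens) for antiproliferative activity, read by sulforhodamine B assay, with a stated time of 48 h (on this read-out lower numbers stand for stronger inhibition of growth and higher numbers for weaker inhibition of growth), compound 1 gives 6020 nM. Compound 2 `Cc1ccc(Nn2c(SCC(=O)Nc3nc(-c4ccccc4)cs3)nc(C)c2C)cc1` reaches only the limit of this assay, where compound 2 gives > 100000 nM, a limit rather than a number. Of the two values shown, one sits at the limit of > 100000 nM in this assay, at which 1 of the 2 values shown sits. Compound 3 `COc1ccc(Nn2c(SCC(=O)Nc3nc(-c4ccc(Cl)cc4)cs3)nc(C)c2C)cc1` has not been measured. It differs from compound 1 by methoxy in place of hydrogen on an aromatic carbon, para to a large group. Among the compounds with values here, no step between measured compounds that differ in a single place is available, and compound 2 differs from compound 1 in more than one place, so its limit offers no direct guide. The expected step in this assay is a 2.5-fold higher number from compound 1 to compound 3 (0.40 log units; beyond the scatter), toward weaker inhibition of growth, with considerable uncertainty about its size. Compound 3 is therefore expected to give 15000 nM in this assay, within a range from 4000 nM to 100000 nM.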

Compound 3, concentration for total growth inhibition: > 100000 nM
Compound 3: no number, only a limit; the forecaster's own chance of this, stated with the estimate: 35%; at least 6.6-fold (0.82 log units) between middle value and limit.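

Within the data shown here, this is the first step in a single place, and in this assay methoxy in place of hydrogen on an aromatic carbon of the anilino ring, para to a large group, brings an at least 16-fold higher number from compound 1 to compound 3 (1.22 log units; beyond the scatter) and so shows that this one change is enough to take the core of compound 1 from a number to a limit. Compound 3 gives > 100000 nM and this is a limit and not a number, so the step is only a minimum: the limit of > 100000 nM in this assay, at which 2 of the 3 values shown sit.

The compounds shown leave open whether fluoro, methyl or an amine at this same carbon would keep the growth inhibition of compound 1. They also leave open how far the true value of compound 3 lies beyond the limit.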